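This account rests on a few compounds, and the source may have more. Where it says the series, first, only, none or still open, it means among the compounds named here.

Compound 1 `COc1ncc(-c2ccc3ncnc(Nc4ccc(OCCO)cc4)c3c2)cc1NS(=O)(=O)c1ccc(F)cc1F`: 1060 nM
Compound 2 `COC(=O)Cn1cc(Nc2ncnc3ccc(-c4cnc(OC)c(NS(=O)(=O)c5ccc(F)cc5F)c4)cc23)cn1`: 1260 nM
Compound 3 `COc1ncc(-c2ccc3ncnc(Nc4ccc(OCCO)c(Cl)c4)c3c2)cc1NS(=O)(=O)c1ccc(F)cc1F`: 7320 nM

In a functional assay on HCT-116 cells (Homo sapiens) for antiproliferative activity, read by sulforhodamine B assay, with a stated time of 72 h (a lower number here means a stronger inhibitor, a higher number a weaker inhibitor), compound 1 sits at the stronger end of these numbers, within the scatter of compound 2 and clearly ahead of compound 3. Compound 4 `COc1ncc(-c2ccc3ncnc(Nc4ccc(OCCO)cc4)c3c2)cc1NS(C)(=O)=O` keeps the rest of compound 1 and changes one group: methyl in place of 2,4-difluorophenyl on a sulfonyl sulfur. This places methyl in place of 2,4-difluorophenyl on a sulfonyl sulfur. Going by the values given here, no measured step touches that group, so the steps elsewhere, a 1.2-fold higher number from compound 1 to compound 2 (0.08 log units; within the scatter) and a 6.9-fold higher number from compound 1 to compound 3 (0.84 log units; beyond the scatter), guide only the likely size. Losing a whole ring is a larger edit than either, so a modest or greater step towards a higher number is expected, though the direction remains a judgement. The expected step is a 4.7-fold higher number from compound 1 to compound 4 (0.67 log units; beyond the scatter). Compound 4 is estimated at 5000 nM, with an expected range of 1500 nM to 20000 nM.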

Compound 4, half-maximal inhibitory concentration: 4860 nM
Beside the measured number, compound 4's estimate is 1.0-fold (0.01 log units) above it, and the stated range covers the measured number.
By their numbers in this assay, from the lowest: compounds 1 and 2 (each within the scatter of the next); then compounds 4 and 3 (each within the scatter of the next).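

Changing the group on the sulfonyl sulfur from 2,4-difluorophenyl to methyl gives, in this assay, a 4.6-fold higher number from compound 1 to compound 4 (0.66 log units; beyond the scatter). This is the only step shown at this position, and it shows that the number depends on this group, although removing the whole ring still leaves activity in the micromolar range. Nothing available explains this shift.

Open, as far as these compounds go, is whether an unsubstituted phenyl ring or a longer chain such as propyl on the sulfonyl sulfur would fall nearer compound 1 or compound 4. From the compounds shown here alone, whether the step would hold alongside the other groups in compound 2 or compound 3 also remains open.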